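Changing the aryl group on a shared pyrimidine-free core

This account rests on a few compounds, and the source may have more. Where it says the series, first, only, none or still open, it means among the compounds named here.

Measured compounds:
- compound 1, `FC(F)(F)c1ccc(NCCNc2ncc(-c3ncc[nH]3)c(-c3ccc(Cl)cc3Cl)n2)nc1`: > 0.5 h
- compound 2, `Clc1ccc(-c2nc(NCCNc3ccccn3)ncc2-c2ncc[nH]2)c(Cl)c1`: > 0.5 h
- compound 3, `Nc1nc(NCCNc2ncc(-c3ncc[nH]3)c(-c3cc(F)ccc3Cl)n2)ccc1[N+](=O)[O-]`: > 0.5 h

All three compounds were tested in an ADME assay on microsomes from liver (Canis lupus familiaris) for metabolic stability; on this read-out lower numbers stand for a shorter-lived compound and higher numbers for a longer-lived compound. None of them gives a number: each value is a limit of this assay. Compound 3 stands at that limit, so its true half-life is not known more closely. Compound 1 and compound 2 differ by hydrogen in place of trifluoromethyl on an aromatic carbon, yet the step that the two limits leave unreadable from compound 1 to compound 2 cannot be read because the limit of > 0.5 h in this assay, at which 3 of the 3 values shown sit, is where both of its ends sit.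

Compound 4, `COc1cc(Cl)ccc1-c1nc(NCCNc2ccc([N+](=O)[O-])c(N)n2)ncc1-c1ncc[nH]1`, differs from compound 3 by 4-chloro-2-methoxyphenyl in place of 2-chloro-5-fluorophenyl on an aromatic carbon. Going by the values given here, no measured step resembles that change, and the three values available show only that every tested member is at least as long-lived as the limit allows. On that basis compound 4 is expected to behave like its neighbours, with the step that the limit leaves unreadable from compound 3 to compound 4 estimated to stay within the scatter. Compound 4 is therefore estimated at 1 h, within a range from 0.5 h to 3 h, most likely reported again only as a limit.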

Compound 4, half-life: > 0.5 h
Compound 4 ended at the assay's limit (the forecaster's own chance of this, stated with the estimate: 85%); the middle value lies beyond the limit too.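

No size can be given for the change from compound 3 to compound 4 in this assay, because both compounds give only a limit, not a number: the limit of > 0.5 h in this assay, at which 4 of the 4 values shown sit.

The true half-lives of these compounds remain open, as does whether 4-chloro-2-methoxyphenyl in place of 2-chloro-5-fluorophenyl changes the half-life at all.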